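A few compounds are considered here, and "the series" means these few. Any claim that something is new, unique, unknown or untested is made for them only; others in the source may bear on it.

Working notes on the series. Compound 1 `COc1ccc(OC)c(N2C(=O)CSC2c2cccc(C(=O)NCCCCc3ccccc3)c2)c1` has been run in a functional assay on SJSA-1 cells (Homo sapiens) for inhibition, read by CCK-8 assay, with a stated time of 72 h, tested at 1 uM (a higher number here means more inhibition at the concentration tested (going by the name of the read-out), a lower number less inhibition), where compound 1 gives 48%. Among the three numbers in hand this is the second highest. The nearest number belongs to compound 3 `COc1ccccc1N1C(=O)CSC1C(=O)NCCCCc1ccccc1`, which in this assay gives 14%, a figure that falls below compound 1 by more than the scatter. The furthest belongs to compound 2 `CCOc1ccccc1N1C(=O)C(C)SC1c1cccc(C(=O)NCCCCc2ccccc2)c1`, which in this assay gives 85%, a figure that rises above compound 1 by more than the scatter. None of these three pairs differs in only one place, so no single step can be read from the measured set; compound 1 and compound 2 share the amide-bearing aryl group on the shared core, whereas compound 3 does not.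

Compound 4 `COc1c(F)cccc1N1C(=O)CSC1c1cccc(C(=O)NCCCCc2ccccc2)c1` is the next one to be measured in this assay. Against compound 1 the change is 3-fluoro-2-methoxyphenyl in place of 2,5-dimethoxyphenyl on an amide-type nitrogen in a ring. Going by the values given here, no measured step of this kind exists here, and the three numbers give no direction for it. The step of a number 2 percentage points higher from compound 1 to compound 4 (within the scatter) is therefore expected to stay within the scatter, with wide uncertainty. Compound 4 is accordingly estimated at 50%, with a range from 25% to 75%.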

Compound 4, a percentage reported as inhibition, at one concentration (the size of the read-out at that concentration, not a potency): 1%
The estimate for compound 4 lay 49 percentage points above the measured number, outside the stated range (below it).
By their numbers in this assay, from the lowest: compound 4; then compound 3; then compound 1; then compound 2.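

Going by these compounds alone, putting 3-fluoro-2-methoxyphenyl in place of 2,5-dimethoxyphenyl on the amide-type nitrogen in a ring gives, in this assay, a number 47 percentage points lower from compound 1 to compound 4 (beyond the scatter), the only step so far that can be read at a single place. The earlier compounds shown here differed in more than one place and could not isolate this position; this step shows that, with the rest of compound 1 unchanged, the choice of aryl group here can by itself take the read-out down to the level of compound 4, which gives 1%. No measurement shown here bears on what lies behind this drop.

As far as these compounds go, the step removes one methoxy and brings in a fluorine together, so it remains open which of the two carries the loss, and a methoxyphenyl group with neither of them on the core of compound 1 would separate the two. Also open, from the compounds shown here alone, are whether a chlorine or an amine in the place of the fluorine would behave the same way, and whether the step holds with the ethoxyphenyl group and ring methyl of compound 2.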